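This account rests on a few compounds, and the source may have more. Where it says the series, first, only, none or still open, it means among the compounds named here.

In an ADME assay on L02 cells (Homo sapiens) for antiproliferative activity, read by MTT assay, with a stated time of 48 h (on this read-out lower numbers stand for stronger inhibition and higher numbers for weaker inhibition), compound 1 `Cc1ccccc1-n1nncc1CN1C(=O)C2(C(C#N)=C(N)Oc3c(N)cc4nc5ccccc5nc4c32)c2ccccc21` gives > 50000 nM, which is a limit of the assay.
In this assay compound 2 `N#CC1=C(N)Oc2c(N)cc3nc4ccccc4nc3c2C12C(=O)N(Cc1cnnn1-c1ccc(Cl)cc1)c1ccccc12` gives > 50000 nM, also a limit.
In this assay compound 3 `CCc1cccc(C)c1-n1nncc1CN1C(=O)C2(C(C#N)=C(N)Oc3c(N)cc4nc5ccccc5nc4c32)c2ccccc21` gives > 50000 nM, again a limit.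

Compound 3 therefore stands only at the limit of > 50000 nM in this assay, at which 3 of the 3 values shown sit, with no number of its own. Compound 4 `Cc1cc(C)cc(-n2nncc2CN2C(=O)C3(C(C#N)=C(N)Oc4c(N)cc5nc6ccccc6nc5c43)c3ccccc32)c1` differs from it in one place: 3,5-dimethylphenyl in place of 2-ethyl-6-methylphenyl on an aromatic nitrogen. The measured steps that bear on this change all swap the group on the same aromatic nitrogen, yet each is unreadable: a step that the two limits leave unreadable from compound 1 to compound 2, a step that the two limits leave unreadable from compound 1 to compound 3 and a step that the two limits leave unreadable from compound 2 to compound 3. They give no direction and no size, so no step beyond the scatter can be predicted in this assay. Compound 4 is expected at 60000 nM, within 30000 nM to 200000 nM, most likely reported again only as a limit. That means an expected step that the limit leaves unreadable from compound 3 to compound 4.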

Compound 4, half-maximal inhibitory concentration: > 50000 nM
Compound 4: a limit, no number (the forecaster's own chance of this, stated with the estimate: 85%); the middle value does not contradict the limit.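

Going by these compounds alone, compound 4, like compound 1, compound 2 and compound 3, gives only a limit and no number, so no step among them can be read: the limit of > 50000 nM in this assay, at which 4 of the 4 values shown sit. As far as these compounds go, how strongly any of them acts, and whether the group on the aromatic nitrogen matters, stays open.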